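Trifluoromethyl in Place of Isopropyl on the Shared Core

The source may hold more compounds than are shown below. What is called first, only, known or untested is meant among the compounds shown, and "the series" means these compounds.

Measured so far in a functional assay with leukotriene B4 receptor (Homo sapiens) as the target; a higher number here means a weaker inhibitor, a lower number a stronger inhibitor:
compound 1 `O=C(O)c1ccc(Cl)cc1-c1ccc2c(c1)OC[C@H](Cc1ccc(C(F)(F)F)cc1)[C@H]2O`, 9000 nM
compound 2 `CC(C)c1ccc(C[C@H]2COc3cc(-c4cc(F)ccc4C(=O)O)ccc3[C@@H]2O)cc1`, 210 nM
compound 3 `O=C(O)c1ccc(F)cc1-c1ccc2c(c1)OC[C@H](Cc1ccc(-c3ccccc3)cc1)[C@H]2O`, 56 nM; 5 nM (2 entries)

Among the two single numbers, compound 2 stands lowest; compound 1 is the nearest, with a number far beyond the scatter, and compound 3 has several entries rather than one number. Compound 4 `O=C(O)c1ccc(F)cc1-c1ccc2c(c1)OC[C@H](Cc1ccc(C(F)(F)F)cc1)[C@H]2O` has not yet been measured in this assay. It differs from compound 2 in one place: trifluoromethyl in place of isopropyl on an aromatic carbon. Among the compounds with values here, no measured pair shows this change, and compound 1 also carries a trifluoromethyl. The step from compound 2 to compound 4 is expected to run toward a weaker inhibitor, beyond the scatter: a 7.1-fold higher number from compound 2 to compound 4 (0.85 log units; beyond the scatter). Compound 4 is therefore estimated at 1500 nM, with a range from 300 nM to 8000 nM.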

Compound 4, half-maximal inhibitory concentration: 1800 nM
The estimate for compound 4 lay 1.2-fold (0.08 log units) below the measured number; low and high end bracket the measured number.
By their numbers in this assay, from the lowest: compound 2; then compound 4; then compound 1.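

In this assay, the change from isopropyl to trifluoromethyl now has a measured pair, and it weakens inhibition: an 8.6-fold higher number from compound 2 to compound 4 (0.93 log units; beyond the scatter). Fluoro in place of chloro, a change elsewhere on the molecule, gives a 5.0-fold lower number from compound 1 to compound 4 (0.70 log units; beyond the scatter), so the high number of compound 1 does not come from trifluoromethyl alone. Nothing given here explains either step.

On these data alone, whether a methyl group or an amine in place of isopropyl would keep inhibition stays open. So does whether fluoro in place of chloro gives a similar step alongside isopropyl.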